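Chloro to Trifluoromethyl: One Ring Substituent Exchanged

The compounds below may be only part of what the source reports. "The series", "measured", "known", "first", "only" and "open" are said of these compounds alone.

Of the compounds shown here, two have been measured in a functional assay on A549 cells (Homo sapiens) for antiproliferative activity, read by MTT assay, with a stated time of 48 h; on this read-out higher numbers stand for weaker inhibition and lower numbers for stronger inhibition. Compound 1 `O=C(/C=C\Nc1ccc(C(F)(F)F)cc1)c1cn(-c2ccccc2)nc1-c1ccccc1` returns only a limit of the assay, > 50000 nM. Compound 2 `O=C(/C=C\Nc1ccc(Cl)cc1)c1cn(-c2ccccc2)nc1-c1ccc(F)cc1` returns 6700 nM, the single finite number shown, so compound 2 stands alone as the one measured value while the other entry sits at the limit of > 50000 nM in this assay, at which 1 of the 2 values shown sits. Compound 3 `O=C(/C=C\Nc1ccc(C(F)(F)F)cc1)c1cn(-c2ccccc2)nc1-c1ccc(F)cc1` has not yet been measured. It differs from compound 2 in one place: trifluoromethyl in place of chloro on an aromatic carbon. Compound 3 thereby carries the same trifluoromethyl group found in compound 1, which gave only a limit in this assay, while its fluoro on the other ring matches compound 2. On that basis, the expected step of a 3.0-fold higher number from compound 2 to compound 3 (0.47 log units; beyond the scatter) is a loss of potency beyond the usual scatter. Compound 3 is therefore expected to give about 20000 nM, somewhere between 6000 nM and 60000 nM, with a real chance that only a limit is reported.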

Compound 3, half-maximal inhibitory concentration: > 50000 nM
Compound 3 gave a limit, no number; the forecaster's own chance of this, stated with the estimate: 35%; at least 2.5-fold (0.39 log units) between middle value and limit.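

At this position, on an aromatic carbon para to a large group, trifluoromethyl in place of chloro brings a clear loss of potency in this assay, with an at least 7.4-fold higher number from compound 2 to compound 3 (0.87 log units; beyond the scatter). For the compounds shown here, until now, trifluoromethyl had been seen only in compound 1, which has no fluoro on the other ring, whereas compound 3 keeps the fluoro of compound 2. Even so, compound 3 still gives only a limit, > 50000 nM. Limits now make up most of the set: the limit of > 50000 nM in this assay, at which 2 of the 3 values shown sit.

Compound 1 and compound 3 both sit at a limit and the step between them cannot be read, which leaves the effect of fluoro in place of hydrogen open. Also open, going by these compounds, is what a methoxy group, an amine or a carboxylic acid would do in place of chloro at this position.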